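One Substituent Swap Carried Across Two Different Cores

This account rests on a few compounds, and the source may have more. Where it says the series, first, only, none or still open, it means among the compounds named here.

Compound 1, `O=C1C=COC(/C=C/c2ccc(C(F)(F)F)cc2)C1`, gives 39.6 uM in a functional assay on 786-0 cells (Homo sapiens) for inhibition, read by sulforhodamine B assay, with a stated time of 48 h; a lower number here means a stronger inhibitor of growth, a higher number a weaker inhibitor of growth. Compound 2, `COc1ccc(/C=C/C2CC(=O)C=CO2)cc1`, gives 192 uM in this assay. Compound 3, `O=C1C=CCC(/C=C/c2ccc(C(F)(F)F)cc2)N1`, gives 128 uM in this assay.

Compound 1 and compound 2 differ in one place: methoxy in place of trifluoromethyl on an aromatic carbon. That change brought a 4.8-fold higher number from compound 1 to compound 2 (0.69 log units; beyond the scatter), a step clearly beyond the usual scatter. Compound 3 keeps the trifluoromethyl group of compound 1 on a different core; how the two cores differ is not broken down here. Its number in this assay lies above that of compound 1, while the gap between compound 3 and compound 2 falls within the usual scatter, so those two cannot be ordered.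

Compound 4, `COc1ccc(/C=C/C2CC=CC(=O)N2)cc1`, is not yet measured. It differs from compound 3 exactly as compound 2 differs from compound 1: methoxy in place of trifluoromethyl on an aromatic carbon. Because the earlier change gave a 4.8-fold higher number from compound 1 to compound 2 (0.69 log units; beyond the scatter), a weakening of similar size is expected here, and the estimated step is a 4.3-fold higher number from compound 3 to compound 4 (0.63 log units; beyond the scatter). Going by the values given here, only one earlier example of this change exists, so the range is drawn wide. Compound 4 is expected to give about 550 uM in this assay, most likely between 200 uM and 1500 uM.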

Compound 4, concentration for growth inhibition (reported as GI): > 1090 uM
Compound 4: only a limit was reported; the forecaster's own chance of this, stated with the estimate: 20%; middle value at least 1.9-fold (0.29 log units) from the limit.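

In this assay, compound 4 is reported as > 1090 uM, which is a limit of the assay and not an exact number. Even so, methoxy in place of trifluoromethyl on an aromatic carbon gives an at least 8.5-fold higher number from compound 3 to compound 4 (0.93 log units; beyond the scatter), so the change points the same way on both cores, toward a weaker inhibitor of growth. This shows that the direction of the change carried over in these two pairs, but it does not show that the size carried over, and two pairs cannot establish a general rule: the same change on two cores in this assay, a 4.8-fold higher number (0.69 log units; beyond the scatter) from compound 1 to compound 2 and an at least 8.5-fold higher number (0.93 log units; beyond the scatter) from compound 3 to compound 4; the limit leaves it open whether they differ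

The compounds shown leave open whether other groups in the same place, such as a chlorine atom, an amine or a carboxylic acid, would fall between trifluoromethyl and methoxy or outside that range. They also leave open whether the same direction would hold on a third core, or with a longer chain in place of methoxy.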